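Swapping the formyl group of compound 3

This account rests on a few compounds, and the source may have more. Where it says the series, first, only, none or still open, it means among the compounds named here.

In a functional assay on A549 cells (Homo sapiens) for cytotoxicity, read by MTT assay, with a stated time of 72 h (on this read-out lower numbers stand for stronger inhibition and higher numbers for weaker inhibition), compound 3 `COc1cc(/C=C/C=O)ccc1OC/C=C(\C)CCC=C(C)C` gives 5000 nM, the lower of the two actual numbers. Compound 1 `COc1cc(/C=C/C=O)cc(OC)c1OC/C=C(\C)CCC=C(C)C` gives 71000 nM. For compound 2 `CC(C)=CCC/C(C)=C/COc1ccc(/C=C/C(=O)O)cc1` the assay reports only a limit, > 100000 nM.

Compound 4 `COc1cc(/C=C/CO)ccc1OC/C=C(\C)CCC=C(C)C` differs from compound 3 by one change, (hydroxymethyl in place of formyl on a double-bonded chain carbon bound to a double-bonded chain carbon), with hydroxymethyl in place of formyl on a double-bonded chain carbon bound to a double-bonded chain carbon. Among the measured compounds shown here, the sole measured step, a 14-fold lower number from compound 1 to compound 3 (1.15 log units; beyond the scatter), is a hydrogen in place of methoxy on an aromatic carbon, so it shows that one change can matter in this assay but does not measure this one. A moderate rise is expected, a 3.0-fold higher number from compound 3 to compound 4 (0.48 log units; beyond the scatter). For compound 4 the estimated value is 15000 nM, with an expected range from 4000 nM to 60000 nM.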

Compound 4, half-maximal inhibitory concentration: 29000 nM
Beside the measured number, compound 4's estimate is 1.9-fold (0.29 log units) below it; the range from low to high includes it.
By their numbers in this assay, from the lowest: compound 3; then compound 4; then compound 1. At a limit, above all of these: compound 2.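

In this assay, hydroxymethyl in place of formyl on a double-bonded chain carbon bound to a double-bonded chain carbon gives a 5.8-fold higher number from compound 3 to compound 4 (0.76 log units; beyond the scatter). Among the compounds shown here, this is the first measured step at this position, and it shows that the number responds to a change here as well as to the methoxy change on the aromatic carbon. Of the two groups, formyl goes with the lower number, but nothing shown gives a cause for the step.

The compounds shown leave open how an amine or a nitrile would read at this position. They also leave open whether the same step would appear on the core of compound 1.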